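The compounds below may be only part of what the source reports. "The series", "measured", "known", "first", "only" and "open" are said of these compounds alone.

Measured compounds:
compound 1 `Cc1cc(C(=O)O)ccc1C(C)N1CCC[C@H](O[C@H](CO)c2cc(Cl)cc(Cl)c2)[C@@H]1c1ccccc1` — "nd" (no result reported) in the activation assay
compound 2 `Cc1cc(C(=O)O)ccc1CN1CCC[C@H](O[C@H](CO)c2cc(Cl)cc(Cl)c2)[C@@H]1c1ccccc1F` — "nd" (no result reported) in the activation assay
compound 3 `Cc1cc(C(=O)O)ccc1CN1C(C)CC[C@H](O[C@H](CO)c2cc(Cl)cc(Cl)c2)[C@@H]1c1ccccc1` — 130000 nM

Compound 1 has no single number in an assay on isolated protein for activation of cGMP-dependent protein kinase 1 (Homo sapiens), read by ADP-Glo, with stated times of 30 min and 2 h; on this read-out lower numbers stand for an effect already at smaller amounts and higher numbers for an effect only at larger amounts of compound: compound 1 gives "nd" (no result reported), meaning no result was reported. Compound 2 stands the same way, with "nd" (no result reported) in this assay. Only compound 3 carries a number; in this assay compound 3 gives 130000 nM, a high value that points to an effect only at large amounts of compound. Compound 4 `Nc1cc(C(=O)O)ccc1CN1CCC[C@H](O[C@H](CO)c2cc(Cl)cc(Cl)c2)[C@@H]1c1ccccc1` has not yet been measured in this assay. It differs from compound 1 by a group of 11 heavy atoms (8 carbon, 1 nitrogen, 2 oxygen; one six-membered aromatic ring of carbon only) in place of a group of 12 heavy atoms (10 carbon, 2 oxygen; one six-membered aromatic ring of carbon only), on an amine nitrogen in a ring, on an amine nitrogen in a ring. Among the compounds with values here, no step between measured compounds is available, so the size of this change cannot be read from any pair; compound 3, which shares the core and the carboxy-bearing benzyl group, is the only anchor. Compound 4 is therefore expected to land in the weak range as well, around 100000 nM, with a plausible spread from 20000 nM to 500000 nM, and a fair chance that this assay reports only a limit for compound 4.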

Compound 4, half-maximal effective concentration: 168000 nM
Beside the measured number, compound 4's estimate is 1.7-fold (0.23 log units) below it; measured number inside the range.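

No step can be read from compound 4, as compound 1 has no single number in this assay and compound 3 differs from compound 4 in more than one place. The compounds shown leave open what the 2-amino-4-carboxybenzyl group itself contributes to activation. No evidence bearing on this result is available.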